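This account rests on a few compounds, and the source may have more. Where it says the series, first, only, none or still open, it means among the compounds named here.

Measured so far in a functional assay on NCI-H460 cells (Homo sapiens) for cytotoxicity, read by MTT assay, with a stated time of 72 h; on this read-out lower numbers stand for stronger inhibition and higher numbers for weaker inhibition:
Compound 1 `CN(C)Cc1ccc2nc(NC(=O)N/N=C/c3cn(Cc4ccccc4Cl)c4ccccc34)sc2c1`: 1600 nM
Compound 2 `CC1CCN(Cc2ccc3nc(NC(=O)N/N=C/c4cn(Cc5ccc(Cl)cc5Cl)c5ccccc45)sc3c2)CC1`: 1660 nM
Compound 3 `CC1CCN(Cc2ccc3nc(NC(=O)N/N=C/c4c[nH]c5ccccc45)sc3c2)CC1`: 4130 nM

Compound 3 gives 4130 nM, the highest of the three numbers, and the values of the other two compounds lie beyond the scatter from it. Compound 4 `CC1CCN(Cc2ccc3nc(NC(=O)N/N=C/c4cn(Cc5ccccc5Cl)c5ccccc45)sc3c2)CC1` differs from compound 3 in one place: 2-chlorobenzyl in place of hydrogen on an aromatic nitrogen. In words, 2-chlorobenzyl stands in place of hydrogen on an aromatic nitrogen.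

For the measured compounds named here, one measured step bears directly on this change: a 2.5-fold higher number from compound 2 to compound 3 (0.40 log units; beyond the scatter). There, hydrogen takes the place of 2,4-dichlorobenzyl on an aromatic nitrogen, a modest step but one beyond the scatter. Run in reverse, it points to a lower number when a substituted benzyl group is added. Compound 1, at 1600 nM, already carries 2-chlorobenzyl, although it differs from compound 4 elsewhere in the molecule. Compound 2, at 1660 nM, lies within the scatter of compound 1.

A modest step to a lower number is therefore expected in this assay, similar in size to the measured one. The estimated change is a 2.5-fold lower number from compound 3 to compound 4 (0.40 log units; beyond the scatter). The expected value for compound 4 is 1650 nM, with an estimated range from 850 nM to 3200 nM.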

Compound 4, half-maximal inhibitory concentration: 1080 nM
The estimate for compound 4 lay 1.5-fold (0.18 log units) above the measured number, within the range that was stated.
By their numbers in this assay, from the lowest: compounds 4, 1 and 2 (each within the scatter of the next); then compound 3.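

In this assay, for the compounds shown here, the step of a 3.8-fold lower number from compound 3 to compound 4 (0.58 log units; beyond the scatter) puts 2-chlorobenzyl in place of hydrogen on an aromatic nitrogen and lies beyond the scatter, so a single chloro on the benzyl group is enough for the drop that had so far been seen only with 2,4-dichlorobenzyl. The two neighbouring comparisons show that the other differences do not separate these compounds: the step of a 1.5-fold lower number from compound 2 to compound 4 (0.19 log units; within the scatter) removes one chloro from an aromatic carbon and the step of a 1.5-fold lower number from compound 1 to compound 4 (0.17 log units; within the scatter) exchanges dimethylamino for 4-methylpiperidin-1-yl, and both stay within the scatter. No measurement is available that accounts for these numbers.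

Still open, going by these compounds, is whether the chloro has any part in the change at all, since a plain unsubstituted benzyl, a methyl or a longer alkyl chain on the same nitrogen would each test how much of the step belongs to the chlorine and how much to the added carbon framework. On these data alone, it is equally open whether an amine or a carboxylic acid on the benzyl ring would keep the number in the range of compounds 1, 2 and 4.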